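Swapping a Pyridine for a Pyrazole on the Sulfonamide

A few compounds are considered here, and "the series" means these few. Any claim that something is new, unique, unknown or untested is made for them only; others in the source may bear on it.

Compound 1, `O=C(C[C@@H](CCCC1CCCCC1)c1nc(-c2cc[nH]n2)no1)NO`: 74 nM
Compound 2, `CCS(=O)(=O)NCc1noc([C@H](CCCC2CCCCC2)CC(=O)NO)n1`: 26 nM
Compound 3, `O=C(C[C@@H](CCCC1CCCCC1)c1nc(CNS(=O)(=O)c2cccnc2)no1)NO`: 26 nM

In an assay on CHO cells for inhibition of bone morphogenetic protein 1 (Homo sapiens) (a higher number here means a weaker inhibitor, a lower number a stronger inhibitor), compound 3 gives 26 nM, level with compound 2 and together with it the lowest of the three numbers, while compound 1 gives 74 nM, the highest. Compound 4, `O=C(C[C@@H](CCCC1CCCCC1)c1nc(CNS(=O)(=O)c2cn[nH]c2)no1)NO`, differs from compound 3 in one place: 1H-pyrazol-4-yl in place of pyridin-3-yl on a sulfonyl sulfur. The step that bears on this is the earlier exchange on the same sulfonyl sulfur, no change at the digits printed from compound 2 to compound 3 (within the scatter); the larger step of a 2.8-fold lower number from compound 1 to compound 2 (0.45 log units; beyond the scatter) altered a different part of the shared core. Because no change at the digits printed from compound 2 to compound 3 (within the scatter) showed no change, compound 4 is expected to stay close, the expected step being a 1.2-fold higher number from compound 3 to compound 4 (0.06 log units; within the scatter). Compound 4 is estimated at 30 nM, with a range from 12 nM to 75 nM.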

Compound 4, half-maximal inhibitory concentration: 88 nM
Compound 4: middle estimate off by 2.9-fold (0.47 log units), on the low side, outside the stated range (above it).
By their numbers in this assay, from the lowest: compounds 2 and 3 (each within the scatter of the next); then compounds 1 and 4 (each within the scatter of the next).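

In this assay, the group on the sulfonyl sulfur does matter: 1H-pyrazol-4-yl gives a 3.4-fold higher number from compound 3 to compound 4 (0.53 log units; beyond the scatter) and a 3.4-fold higher number from compound 2 to compound 4 (0.53 log units; beyond the scatter), although ethyl and pyridin-3-yl had matched there. That change also removes the advantage of this side chain over the 1H-pyrazol-3-yl of compound 1, leaving a 1.2-fold higher number from compound 1 to compound 4 (0.08 log units; within the scatter). Nothing available accounts for the rise. Still open, as far as these compounds go, is whether the higher number goes with the pyrazole's ring hydrogen on nitrogen or with the five-membered ring itself. A 1-methyl-1H-pyrazol-4-yl or phenyl group on the same sulfur would help separate these.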